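The compounds below may be only part of what the source reports. "The series", "measured", "known", "first", "only" and "open" are said of these compounds alone.

Of the compounds shown here, three have so far been measured in an ADME assay on L1210/0 cells (Mus musculus) for cytotoxicity, with a stated time of 48 h; a lower number here means a stronger inhibitor, a higher number a weaker inhibitor. Compound 1 `CO[C@@H]1OC[C@@H](OC(C)=O)[C@@H](OC(C)=O)[C@]1(F)n1ccc(=O)[nH]c1=O` gives 55000 nM, compound 2 `O=C1O/C(=C\Cn2ccc(=O)[nH]c2=O)C(OCc2ccccc2)=C1OCc1ccccc1` gives 12900 nM, and compound 3 `N#CSc1cn([C@H]2C[C@H](O)[C@@H](CO)O2)c(=O)[nH]c1=O` gives 78900 nM. Compound 3 thus has the highest number of the three: its number and that of compound 1 lie within the scatter, so nothing separates them, whereas the gap to compound 2 lies beyond the scatter. Compound 4 `O=c1[nH]c(=O)n([C@H]2C[C@H](O)[C@@H](CO)O2)cc1C#Cc1ccccc1` keeps the rest of compound 3 and alters one group: 2-phenylethynyl in place of cyanosulfanyl on an aromatic carbon. Among the compounds with values here, no measured pair shows how such a change moves this assay, so the expectation rests on the three numbers alone. The expected step is a 3.9-fold lower number from compound 3 to compound 4 (0.60 log units; beyond the scatter), toward a lower number, of a size that may pass the scatter. Compound 4 is therefore estimated at 20000 nM in this assay, within a range from 4000 nM to 100000 nM.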

Compound 4, half-maximal inhibitory concentration: > 200000 nM
Compound 4: no number, only a limit; the forecaster's own chance of this, stated with the estimate: 20%; middle value at least 10-fold (1.00 log units) from the limit.
By their numbers in this assay, from the lowest: compound 2; then compounds 1 and 3 (each within the scatter of the next). At a limit, above all of these: compound 4.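

In this assay, 2-phenylethynyl in place of cyanosulfanyl on this aromatic carbon gives an at least 2.5-fold higher number from compound 3 to compound 4 (0.40 log units; beyond the scatter) as the only single-place comparison shown, so this position does respond to a change of group, and this change moves toward weaker inhibition. Compound 4 gives > 200000 nM as a limit of the assay, not a number. From the compounds shown here alone, the step therefore has only a lower bound, and its true size stays unknown: the limit of > 200000 nM in this assay, at which 1 of the 4 values shown sits.

The compounds shown leave open whether an amine or a plain ethynyl group at this carbon would hold the number near that of compound 3.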